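The compounds below may be only part of what the source reports. "The series", "measured", "known", "first", "only" and "open" are said of these compounds alone.

Measured so far:

Compound 2 `Cc1cccc(-c2nc3ccc(C)cc3c(=O)[nH]2)c1`: 12.7%
Compound 1 `COc1cccc(-c2nc3ccc(N4CCCCC4)cc3c(=O)[nH]2)c1OC`: 0%

In an assay on isolated protein for inhibition of DNA topoisomerase 1 (Homo sapiens), with a stated time of 30 min, tested at 20 uM (a lower number here means a weaker effect, a higher number a stronger effect of the compound at the concentration tested), compound 2 gives 12.7%, the higher of the two numbers seen so far. Compound 1 gives 0%, a reading that lies below that of compound 2 by more than the usual scatter of this kind of measurement. For the measured compounds named here, compound 1 and compound 2 differ in several places at once, so the gap between them cannot be tied to any single change, and no measured pair of compounds separated by one change is available here.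

Compound 3 `Cc1ccc2nc(-c3cccc(F)c3)[nH]c(=O)c2c1` has not yet been measured. It differs from compound 2 in one place only: fluoro in place of methyl on an aromatic carbon. The exchange swaps one heavy atom for one heavy atom, adds no ring, and changes neither hydrogen-bond donors nor acceptors. Going by the values given here, with no measured step to lean on, the expected step in this assay from compound 2 to compound 3 is small, at most a slight drift downward, and most likely within the scatter: a number 3.7 percentage points lower from compound 2 to compound 3 (within the scatter). On that basis compound 3 is estimated to give 9%, with a range from 0% to 22%.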

Compound 3, a percentage reported as inhibition, at one concentration (the size of the read-out at that concentration, not a potency): 0.2%
The estimate for compound 3 lay 8.8 percentage points above the measured number; the measured number falls inside the stated range.
By their numbers in this assay, from the lowest: compounds 1 and 3 (each within the scatter of the next); then compound 2.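

The reading in this assay is a number 12.5 percentage points lower from compound 2 to compound 3 (beyond the scatter) and this is the only gap so far that can be tied to a single change: fluoro in place of methyl on an aromatic carbon, meta to a large group. It shows that the read-out at this position depends on which group sits there, even though the exchange swaps one heavy atom for one heavy atom and leaves hydrogen-bond donors and acceptors unchanged. Nothing at hand accounts for the drop, so the step records what happens at this position and not why it happens.

A single exchange cannot show whether methyl is itself helpful or fluoro is unfavourable here, or whether a chlorine atom, a methoxy group, an amine or a carboxylic acid at the same place would give a higher or lower reading. Going by these compounds, it also remains open whether the same exchange would have a similar effect on a compound carrying other groups elsewhere on the shared core, such as the piperidine ring and the two methoxy groups of compound 1.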